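Branching the pentyl chain of compound 2

The source may hold more compounds than are shown below. What is called first, only, known or untested is meant among the compounds shown, and "the series" means these compounds.

Measured in a functional assay on brain (Rattus norvegicus, strain Wistar) for inhibition; on this read-out higher numbers stand for weaker inhibition and lower numbers for stronger inhibition:
Compound 1 `Cc1[nH]c(=O)n(C)c1-c1ccc(OC(C)C)cc1` gives 20400 nM
Compound 2 `CCCCCOc1ccc(-c2c(C)[nH]c(=O)n2C)cc1` gives 4500 nM

Of the two measured compounds, compound 2 holds the lower number, at 4500 nM, and so is the stronger inhibitor of the pair. Compound 3 `Cc1[nH]c(=O)n(C)c1-c1ccc(OCCC(C)C)cc1` has not yet been measured. It differs from compound 2 by isopropyl in place of propyl on a saturated chain carbon, two bonds along the chain from an oxygen on an aromatic ring. In words, isopropyl stands in place of propyl on a saturated chain carbon, two bonds along the chain from an oxygen on an aromatic ring, which also reads as pentyl to isopentyl.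

Within the data shown here, the only measured step that bears on this is a 4.5-fold lower number from compound 1 to compound 2 (0.66 log units; beyond the scatter). It bears only loosely, as it exchanges isopropyl for pentyl on the oxygen, whereas the new change keeps the same atoms, joined differently. No step beyond the scatter is therefore expected in this assay. The estimated change is a 1.2-fold higher number from compound 2 to compound 3 (0.09 log units; within the scatter). For compound 3 the expected value is 5500 nM, with an estimated range from 2500 nM to 12000 nM.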

Compound 3, half-maximal inhibitory concentration: 6600 nM
Estimate against measurement, compound 3: 1.2-fold (0.08 log units) below; low and high end bracket the measured number.
By their numbers in this assay, from the lowest: compounds 2 and 3 (each within the scatter of the next); then compound 1.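

The branch on this saturated chain carbon, two bonds along the chain from an oxygen on an aromatic ring, leaves the read-out in this assay within the scatter (a 1.5-fold higher number from compound 2 to compound 3 (0.17 log units; within the scatter)). Among these compounds, this is the first evidence on the shape of the chain rather than on its identity, and here pentyl and isopentyl cannot be told apart. Isopentyl also stands clear of the isopropyl group of compound 1 (a 3.1-fold lower number from compound 1 to compound 3 (0.49 log units; beyond the scatter)), so among these compounds the advantage over isopropyl does not require an unbranched chain. Nothing available explains why the branch makes so little difference or why either chain differs from isopropyl.

The compounds shown leave open whether the same holds for a branch elsewhere on the chain, as in a 2-methylbutyl group, or for a longer chain such as hexyl or a ring such as cyclopentyl. They also do not show how a terminal amine or carboxylic acid on the chain would read, or whether any such change would bring the numbers well below those of compound 2 and compound 3.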